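Fluoro for Hydrogen and Clearance in Liver Microsomes

The compounds below may be only part of what the source reports. "The series", "measured", "known", "first", "only" and "open" are said of these compounds alone.

Compound 1, `Fc1cc(Cl)ccc1-c1ccc(Cn2nnc3ccccc32)cn1`: in an ADME assay on microsomes from liver (Homo sapiens) for metabolic stability, tested at 2.5 uM (a higher number here means faster removal of the compound, a lower number slower removal), compound 1 gives 0.01 mL/min/g.
Compound 2, `Fc1ccc2nnn(Cc3ccc(-c4ccc(Cl)cc4F)nc3)c2c1`: compound 2 gives 0.1 mL/min/g.
Compound 3, `Clc1ccc(Cn2nnc3c(Br)cccc32)cc1`: compound 3 gives 0.6 mL/min/g.

The one counted change among these, (fluoro in place of hydrogen on an aromatic carbon), made a 10-fold higher number from compound 1 to compound 2 (1.00 log units; beyond the scatter). Compound 4, `Fc1cc(Cl)ccc1Cn1nnc2c(Br)cccc21`, is not yet measured; it carries fluoro in place of hydrogen on an aromatic carbon. This is the same kind of change as the earlier one, but its surroundings differ: here the carbon is ortho to a large group and meta to a chloro group, whereas in compound 2 it is part of a fused system of two rings, meta and para to a fused ring. The difference between the cores of compound 3 and compound 1 is not broken down here. Compound 3 stands highest of the three. For the measured compounds named here, for compound 4 an upward step is expected, a 2.5-fold higher number from compound 3 to compound 4 (0.40 log units; beyond the scatter), resting on a 10-fold higher number from compound 1 to compound 2 (1.00 log units; beyond the scatter), with a broad range because only one such step is known. Compound 4 is estimated at 1.5 mL/min/g, between 0.5 mL/min/g and 5 mL/min/g.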

Compound 4, intrinsic clearance in a liver preparation (reported as CLH), per the amount of preparation that the assay uses: 0.5 mL/min/g
The estimate for compound 4 lay 3.0-fold (0.48 log units) above the measured number, and the stated range covers the measured number.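

In this assay, for the compounds shown here, fluoro in place of hydrogen on an aromatic carbon gave a 1.2-fold lower number from compound 3 to compound 4 (0.08 log units; within the scatter), so on the core of compound 3 the change produced no step that can be told from the scatter. The earlier step therefore did not carry over from one core to the other: the same change on two cores in this assay, a 10-fold higher number (1.00 log units; beyond the scatter) from compound 1 to compound 2 and a 1.2-fold lower number (0.08 log units; within the scatter) from compound 3 to compound 4, 12-fold (1.08 log units) apart, beyond the scatter of two such steps. This does not show which difference between the two cores or between the two places of the fluoro separates the steps, and two steps give no rule for any further core.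

The compounds shown leave open whether a methoxy group or a nitrile in place of the fluoro would differ between the two cores in the same way. They also leave open how an amine or a carboxylic acid in place of the bromo would move the number.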